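Allyl to propargyl on a thioether-linked triazole phthalimide

This account rests on a few compounds, and the source may have more. Where it says the series, first, only, none or still open, it means among the compounds named here.

Compound 1, `C=CCSc1nnc(CCC)n1N1C(=O)c2ccccc2C1=O`: in a functional assay on A549 cells (Homo sapiens) for cytotoxicity, read by MTT assay, with a stated time of 48 h (on this read-out lower numbers stand for stronger inhibition and higher numbers for weaker inhibition), compound 1 gives > 200000 nM, a limit of the assay.
Compound 2, `CCCc1nnc(SCC(=O)c2ccc(C)cc2)n1N1C(=O)c2ccccc2C1=O`: in this assay compound 2 gives > 200000 nM, a limit of the assay.

Compound 2 stands at the limit of this assay, and so does compound 1, which together give (the limit of > 200000 nM in this assay, at which 2 of the 2 values shown sit). The step that the two limits leave unreadable from compound 1 to compound 2 is therefore unreadable. Compound 3, `C#CCSc1nnc(CCC)n1N1C(=O)c2ccccc2C1=O`, differs from compound 2 by ethynyl in place of (4-methylphenyl)carbonyl on a saturated chain carbon bound to a sulfur; the propargyl group resembles the allyl group of compound 1 more than the ketone of compound 2. Since both measured compounds sit at the limit, no readable step bears on this change, and compound 3 is expected to give only a limit as well, with the step that the limit leaves unreadable from compound 2 to compound 3 unreadable. Compound 3 is estimated at 300000 nM, in the range 100000 nM to 1000000 nM.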

Compound 3, half-maximal inhibitory concentration: > 200000 nM
Compound 3: only a limit was reported (the forecaster's own chance of this, stated with the estimate: 85%); the middle value does not contradict the limit.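

Going by these compounds alone, no step among compound 1, compound 2 and compound 3 can be read in this assay, as each gives only a limit: the limit of > 200000 nM in this assay, at which 3 of the 3 values shown sit. The compounds shown leave open whether ethynyl, vinyl and (4-methylphenyl)carbonyl differ at all in this assay.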